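Chloro on the shared core and tolerated concentration

The compounds below may be only part of what the source reports. "The series", "measured", "known", "first", "only" and "open" are said of these compounds alone.

Measured so far in an ADME assay on MT2 cells (Homo sapiens) for cytotoxicity, read by MTT assay; a higher number here means that more compound is tolerated, a lower number that less compound is tolerated:
Compound 1 `N#Cc1ccc2c(Oc3ccccc3OCCn3ccc(=O)[nH]c3=O)cc(F)cc2c1` gives > 100000 nM, a limit of the assay.
Compound 2 `N#Cc1cc2c(Oc3ccccc3OCCn3ccc(=O)[nH]c3=O)cccc2o1` gives > 100000 nM, also a limit of the assay.
Compound 3 `N#Cc1ccc2c(Oc3ccc(Cl)cc3OCCn3ccc(=O)[nH]c3=O)cc(F)cc2c1` gives 18000 nM.

The difference between the cores of compound 1 and compound 2 is not broken down here. Compound 3 differs from compound 1 by chloro in place of hydrogen on an aromatic carbon, and this change gave an at least 5.5-fold lower number from compound 1 to compound 3 (0.74 log units; beyond the scatter); the step can only be bounded, since (the limit of > 100000 nM in this assay, at which 2 of the 3 values shown sit).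

Compound 4 `N#Cc1cc2c(Oc3ccc(Cl)cc3OCCn3ccc(=O)[nH]c3=O)cccc2o1` has not yet been measured. It differs from compound 2 by chloro in place of hydrogen on an aromatic carbon, the same change as that from compound 1 to compound 3, at a place described in the same words. For compound 4 in this assay a step of an at least 5.0-fold lower number from compound 2 to compound 4 (0.69 log units; beyond the scatter) is expected, resting on the earlier at least 5.5-fold lower number from compound 1 to compound 3 (0.74 log units; beyond the scatter), with the caution that compound 2 itself sits at a limit. Compound 4 is therefore estimated at 20000 nM, between 7000 nM and 100000 nM.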

Compound 4, half-maximal cytotoxic concentration: 7000 nM
The estimate for compound 4 lay 2.9-fold (0.46 log units) above the measured number, within the range that was stated.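

In this assay, chloro in place of hydrogen on an aromatic carbon gave an at least 14-fold lower number from compound 2 to compound 4 (1.15 log units; beyond the scatter), so the change lowers the tolerated concentration on both cores shown, beyond the scatter on each. This shows that the direction of the step carries from one core to the other, but not that its size does: the same change on two cores in this assay, an at least 5.5-fold lower number (0.74 log units; beyond the scatter) from compound 1 to compound 3 and an at least 14-fold lower number (1.15 log units; beyond the scatter) from compound 2 to compound 4; the limit leaves it open whether they differ. Neither step has an exact size, and the parent of each is only a limit: the limit of > 100000 nM in this assay, at which 2 of the 4 values shown sit.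

The compounds shown leave open whether this drop is specific to chloro or would also follow from fluoro, methyl, methoxy or an amine at the same place. They also leave open whether it holds on any further core.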